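The compounds below may be only part of what the source reports. "The series", "measured", "known", "first", "only" and "open" are said of these compounds alone.

Compound 1 `CCOC(=O)c1csc2nc(CN3CCN(C)CC3)c(-c3ccc(C)cc3)n12` gives 65000 nM in a functional assay on PC-3 cells (Homo sapiens) for antiproliferative activity, read by MTT assay, with a stated time of 72 h; on this read-out lower numbers stand for stronger inhibition and higher numbers for weaker inhibition. Compound 2 `CCOC(=O)c1csc2nc(CN3CCN(C)CC3)c(-c3ccc(OC)cc3)n12` gives 69400 nM in this assay. Compound 3 `CC(=O)NNC(=O)c1csc2ncc(-c3ccc(C)cc3)n12` gives 92700 nM in this assay.

Compounds 1 and 2 share a core and differ in one place: methoxy in place of methyl on an aromatic carbon. That change makes a 1.1-fold higher number from compound 1 to compound 2 (0.03 log units; within the scatter). Compound 3 is built on a different core; the difference between the two cores is not broken down here. Its number in this assay lies within the scatter of those of compound 1 and compound 2, so the three measured values show no order among them.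

Compound 4 `COc1ccc(-c2cnc3scc(C(=O)NNC(C)=O)n23)cc1` has not yet been measured. It carries the core of compound 3 with one change: methoxy in place of methyl on an aromatic carbon. The place is described in the same words as for the step from compound 1 to compound 2, so this is the same change made on the other core.

Among the compounds with values here, since the only measured instance of this change, from compound 1 to compound 2, stayed within the scatter, compound 4 is expected to sit close to compound 3, with an expected step of a 1.1-fold higher number from compound 3 to compound 4 (0.03 log units; within the scatter) in this assay. That expectation rests on compound 1 and compound 2 and their step of a 1.1-fold higher number from compound 1 to compound 2 (0.03 log units; within the scatter). In this assay compound 4 is estimated at 100000 nM, with a range from 55000 nM to 200000 nM.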

Compound 4, half-maximal inhibitory concentration: 28300 nM
For compound 4 the middle estimate is 3.5-fold (0.55 log units) above the measured one, outside the stated range (below it).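

In this assay, methoxy in place of methyl, on an aromatic carbon para to a large group, gives a 3.3-fold lower number from compound 3 to compound 4 (0.52 log units; beyond the scatter), so on the core of compound 3 the swap moves the number clearly, and the two instances of the change do not agree: the same change on two cores in this assay, a 1.1-fold higher number (0.03 log units; within the scatter) from compound 1 to compound 2 and a 3.3-fold lower number (0.52 log units; beyond the scatter) from compound 3 to compound 4, 3.5-fold (0.54 log units) apart, beyond the scatter of two such steps

The change therefore did not carry over unaltered from one core to the other in this series, and a step read on the core of compound 1 proved a poor guide to the step on the core of compound 3. What this does not show is which feature of the cores lies behind the gap, since the two cores differ in more than one place and no compound shown separates those differences, and two pairs are too few to support a general rule for either core.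

The compounds shown leave open whether another group at the same place, such as a chlorine, a hydroxyl or an ethoxy chain, would follow methoxy or methyl on the core of compound 3. They also leave open whether the step on that core would survive if its acetyl hydrazide were replaced by an ethyl ester or a carboxylic acid.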